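Cyclohexyl in place of 4-fluorophenyl on a long chain

A few compounds are considered here, and "the series" means these few. Any claim that something is new, unique, unknown or untested is made for them only; others in the source may bear on it.

Among the measured compounds shown here, in a functional assay on PANC-1 cells (Homo sapiens) for cytotoxicity, read by WST assay, with a stated time of 24 h (on this read-out lower numbers stand for stronger inhibition and higher numbers for weaker inhibition), compound 3 (`O=C(CCCCCCCCc1ccc(F)cc1)N1CCCCC1`) gives 99800 nM, the only true number so far. Compound 1 (`O=C(CCCCCCCCCc1ccccc1)N1CCCCC1`) gives > 100000 nM, which is a limit of the assay. Compound 2 (`Cc1ccc(CCCCCCCCC(=O)N2CCCCC2)cc1`) gives > 100000 nM, also a limit.

Compound 4 (`O=C(CCCCCCCCC1CCCCC1)N1CCCCC1`) differs from compound 3 in one place: cyclohexyl in place of 4-fluorophenyl on a saturated chain carbon, eight bonds along the chain from a carbonyl carbon. This puts cyclohexyl in place of 4-fluorophenyl on a saturated chain carbon, eight bonds along the chain from a carbonyl carbon.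

Three measured steps change the group at this place: a step that the two limits leave unreadable from compound 1 to compound 2, then a number no higher from compound 1 to compound 3 (the limit leaves the size open), and a number no higher from compound 2 to compound 3 (the limit leaves the size open). None has a readable size because of the limit of > 100000 nM in this assay, at which 2 of the 3 values shown sit. None of them brings in a non-aromatic ring.

Compound 3 at 99800 nM already shows weak inhibition, so only a small move toward weaker inhibition is expected. The expected step is a 1.1-fold higher number from compound 3 to compound 4 (0.04 log units; within the scatter). For compound 4 the estimate is 110000 nM, with an expected range from 50000 nM to 220000 nM.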

Compound 4, half-maximal inhibitory concentration: > 100000 nM
Compound 4 was reported as a limit; the forecaster's own chance of this, stated with the estimate: 65%; the middle value lies beyond the limit too.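

Compound 4 is the first compound shown with a non-aromatic ring at this place, and putting cyclohexyl in place of 4-fluorophenyl gives a number no lower from compound 3 to compound 4 (the limit leaves the size open), so the change brings no stronger inhibition. In this assay compound 4 gives > 100000 nM, which is a limit and not a number. The size of that step, and of the steps linking compound 4 with compound 1 and compound 2, cannot be read because so many values stop at the same point: the limit of > 100000 nM in this assay, at which 3 of the 4 values shown sit.

All the ring groups shown at this place carry only carbon, apart from the fluorine of compound 3. From the compounds shown here alone, whether an amine or a carboxylic acid at the end of the chain, or a shorter chain, would bring the number clearly under this limit stays open.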